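Working notes on cytotoxicity for compounds 2 and 3

This account rests on a few compounds, and the source may have more. Where it says the series, first, only, none or still open, it means among the compounds named here.

Measured so far:
compound 1, `COc1ccc(C2CC(c3cc4ccccc4o3)=NN2C(=O)c2ccncc2)cc1`: > 200000 nM
compound 2, `CCn1cc(C(=O)N2N=C(c3cc4ccccc4o3)CC2c2ccccc2OC)c(=O)c2ccc(C)nc21`: > 187000 nM

In an ADME assay on Vero cells (Chlorocebus sabaeus) for cytotoxicity, read by MTT assay, with a stated time of 72 h (a lower number here means a stronger inhibitor, a higher number a weaker inhibitor), compound 1 returns only a limit, > 200000 nM. In this assay compound 2 likewise returns only a limit, > 187000 nM. For the measured compounds named here, neither value is a number, so no step between compound 1 and compound 2 can be read; both simply sit at the edge of what this assay reports, as recorded in the limit of > 187000 nM in this assay, at which 1 of the 2 values shown sits, and (the limit of > 200000 nM in this assay, at which 1 of the 2 values shown sits). Compound 2 therefore stands at a limit, with nothing measurable to compare against.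

Compound 3, `CCn1cc(C(=O)N2N=C(c3cc4ccccc4o3)CC2c2ccccc2Cl)c(=O)c2ccc(C)nc21`, differs from compound 2 in one place: chloro in place of methoxy on an aromatic carbon, ortho to a large group. Going by the values given here, no measured step exists to gauge this exchange. With both known values at limits, the expectation for compound 3 is that the exchange produces no shift beyond the scatter, so the step expected is a step that the limit leaves unreadable from compound 2 to compound 3. For compound 3 the estimate in this assay is 200000 nM, with a range from 50000 nM to 400000 nM, most likely reported again as a limit.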

Compound 3, half-maximal inhibitory concentration: > 178000 nM
Compound 3: no number, only a limit; the forecaster's own chance of this, stated with the estimate: 80%; the middle value is on the limit's open side.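

In this assay compound 3 returns > 178000 nM, which is a limit and not a number. Compound 2 also stands at a limit, and no step can be read between compound 2 and compound 3. Left open is whether chloro in place of methoxy on an aromatic carbon changes cytotoxicity at all: no compound shown gives a number in this assay.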